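This account rests on a few compounds, and the source may have more. Where it says the series, first, only, none or still open, it means among the compounds named here.

Measured so far:
Compound 1, `CCCCCCCCCCCCCCC(COCc1ccccc1)NC(=O)CCCC(=O)O`, gives > 50000 nM in a functional assay on Jurkat cells (Homo sapiens) for inhibition; on this read-out higher numbers stand for weaker inhibition and lower numbers for stronger inhibition; this value is a limit of the assay, not a number.
Compound 2, `CCCCCCCCCCCCCCC(CO)N(CC)CC`, gives 1000 nM in this assay.

Within the data shown here, compound 2 thus stands at the only plain number among the values shown. Compound 1 sits at the limit of > 50000 nM in this assay, at which 1 of the 2 values shown sits.

Compound 3, `CCCCCCCCCCCCCCC(COCc1ccccc1)N(CC)CC`, has not yet been measured. It differs from compound 2 by benzyl in place of hydrogen on an oxygen on a saturated carbon, which reads, cut one bond further out, hydroxy to benzyloxy. Among the measured compounds shown here, no measured pair shows this change by itself, so the size of the step in this assay is open. Compound 1 carries the same benzyloxy group, but it differs from compound 2 in other places as well, so that pair gives no clean reading of this one change.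

The expected step is a 2.0-fold higher number from compound 2 to compound 3 (0.30 log units; within the scatter), a modest move toward weaker inhibition, held with wide uncertainty. Compound 3 is estimated at 2000 nM, with a likely range from 500 nM to 10000 nM.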

Compound 3, half-maximal inhibitory concentration: 20000 nM
The estimate for compound 3 lay 10-fold (1.00 log units) below the measured number; measured number outside the range, above it.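

In this assay, the change from hydroxy to benzyloxy can now be read by itself, with the diethylamino group and the long chain held constant: it gives a 20-fold higher number from compound 2 to compound 3 (1.30 log units; beyond the scatter), so at this position the free hydroxy compound is clearly the stronger inhibitor of the pair. The same compound gives a second clean comparison, this time with benzyloxy held constant, and diethylamino in place of ((3-carboxypropyl)carbonyl)amino gives an at least 2.5-fold lower number from compound 1 to compound 3 (0.39 log units; beyond the scatter), so the diethylamino compound shows the stronger inhibition of these two. Compound 1 stands at a limit of the assay and not at a number, so the true size of this second step stays unknown: the limit of > 50000 nM in this assay, at which 1 of the 3 values shown sits.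

The compounds shown cannot tell whether the loss belongs to the benzyl group in particular or would follow from any group on that oxygen, a question that a smaller methoxy or a larger naphthylmethoxy in the same place would address. They also leave open how far the inhibition depends on the amine itself, for example whether a dimethylamino group or a plain primary amine would serve as well as diethylamino.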